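Methyl to bromo: the step from compound 1 to compound 4

The source may report more compounds than this note shows. Statements on the series, on what has been measured and on what is new or still open speak of the compounds shown alone.

Compound 1 `Cc1ccc(NS(=O)(=O)c2ccc(N3CCNC3=O)cc2)cc1` gives in a functional assay on MCF7 cells (Homo sapiens) for antiproliferative activity, read by sulforhodamine B assay, with a stated time of 48 h (on this read-out lower numbers stand for stronger inhibition and higher numbers for weaker inhibition), 610 nM and stands lowest of the two plain numbers in the set. Compound 2 `O=C1NCCN1c1ccc(S(=O)(=O)Nc2ccc(F)cc2)cc1` gives 690 nM in this assay, and a 1.1-fold higher number from compound 1 to compound 2 (0.05 log units; within the scatter). Compound 3 `CC(C)(C)c1ccc(NS(=O)(=O)c2ccc(N3CCNC3=O)cc2)cc1` yields only a limit in this assay, > 1000 nM; this rests on (the limit of > 1000 nM in this assay, at which 1 of the 3 values shown sits). Across the other steps, an at least 1.6-fold higher number from compound 1 to compound 3 (0.21 log units; that floor lies within the scatter) and an at least 1.4-fold higher number from compound 2 to compound 3 (0.16 log units; that floor lies within the scatter). Compound 4 `O=C1NCCN1c1ccc(S(=O)(=O)Nc2ccc(Br)cc2)cc1` differs from compound 1 thus: bromo in place of methyl on an aromatic carbon. The step from compound 1 to compound 2 bears most, and it stayed within the scatter. The step to compound 3 shows a weakening only as a limit. For compound 4 the expected change is a 1.1-fold higher number from compound 1 to compound 4 (0.05 log units; within the scatter), with the estimate placed at 680 nM between 350 nM and 1300 nM.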

Compound 4, half-maximal inhibitory concentration: 240 nM
Compound 4: middle estimate off by 2.8-fold (0.45 log units), on the high side; the whole stated range lies above it.
By their numbers in this assay, from the lowest: compound 4; then compounds 1 and 2 (each within the scatter of the next). At a limit, above all of these: compound 3.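

In this assay this position, on an aromatic carbon para to a large group, now shows a change beyond the scatter: bromo lowers the number against methyl (a 2.5-fold lower number from compound 1 to compound 4 (0.41 log units; beyond the scatter)) and against fluoro (a 2.9-fold lower number from compound 2 to compound 4 (0.46 log units; beyond the scatter)). The earlier swap of methyl for fluoro at this carbon had left the number within the scatter. Against tert-butyl the number also falls (an at least 4.1-fold lower number from compound 3 to compound 4 (0.61 log units; beyond the scatter)), but that step is only a floor, since compound 3 stands at a limit: (the limit of > 1000 nM in this assay, at which 1 of the 4 values shown sits).

On these data alone, whether chloro, iodo, an amine or a carboxylic acid at this carbon would match bromo remains open.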